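Trifluoromethyl for hydrogen on a second aromatic ring

A few compounds are considered here, and "the series" means these few. Any claim that something is new, unique, unknown or untested is made for them only; others in the source may bear on it.

Compound 1 `O=S(=O)(NCCCNCc1ccc(C(F)(F)F)cc1)c1cc(C(F)(F)F)cc(C(F)(F)F)c1` and compound 2 `O=S(=O)(NCCCNCc1ccccc1)c1cc(C(F)(F)F)cc(C(F)(F)F)c1` share one core. In a functional assay on MIA PaCa-2 cells (Homo sapiens) for inhibition, read by MTT assay, with a stated time of 72 h (a higher number here means a weaker inhibitor of growth, a lower number a stronger inhibitor of growth), compound 2 gives 11000 nM, and compound 1 gives 2500 nM. The change between them is trifluoromethyl in place of hydrogen on an aromatic carbon, and it makes a 4.4-fold lower number from compound 2 to compound 1 (0.64 log units; beyond the scatter).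

Compound 3 `O=S(=O)(NCCCCCCNCc1ccc(Br)cc1)c1c(Cl)cccc1Cl` has a different core; the difference between the two cores is not broken down here. In this assay compound 3 gives 14700 nM, which sits within the scatter of compound 2 and above compound 1.

Compound 4 `O=S(=O)(NCCCCCCNCc1ccc(Br)cc1)c1c(Cl)cc(C(F)(F)F)cc1Cl` is compound 3 with trifluoromethyl in place of hydrogen on an aromatic carbon. This is the same kind of change as that from compound 2 to compound 1, not the same: in compound 4 the new group sits meta to two chloro groups as well as para to a large group, whereas in compound 1 it is only para to a large group, on a different ring of the molecule.

For compound 4 a step of a 2.5-fold lower number from compound 3 to compound 4 (0.39 log units; beyond the scatter) is expected in this assay, smaller than a 4.4-fold lower number from compound 2 to compound 1 (0.64 log units; beyond the scatter). Compound 4 is estimated at 6000 nM, within 2500 nM to 15000 nM.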

Compound 4, concentration for 50% growth inhibition: 5670 nM
Beside the measured number, compound 4's estimate is 1.1-fold (0.02 log units) above it, and the stated range covers the measured number.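

In this assay, trifluoromethyl in place of hydrogen on an aromatic carbon gives a 2.6-fold lower number from compound 3 to compound 4 (0.41 log units; beyond the scatter), so the number also falls on this second core. The two steps run in the same direction and cannot be told apart in size: the same change on two cores in this assay, a 4.4-fold lower number (0.64 log units; beyond the scatter) from compound 2 to compound 1 and a 2.6-fold lower number (0.41 log units; beyond the scatter) from compound 3 to compound 4, 1.7-fold (0.23 log units) apart, within the scatter of two such steps. This shows the change carrying over between these two cores, even though the new group sits on a different ring of the molecule in each pair, but two pairs do not establish a rule for the series, and they do not show why the number falls or predict the step on any further core.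

As far as these compounds go, it remains open whether a nitrile or a methyl group on the same aromatic carbon would give a step of similar size. From the compounds shown here alone, it is also open whether trifluoromethyl would keep its step on a core with a longer chain, or with an amide in place of the amine.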